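The source may hold more compounds than are shown below. What is called first, only, known or untested is meant among the compounds shown, and "the series" means these compounds.

In a functional assay on BT-474 cells (Homo sapiens) for antiproliferative activity, read by sulforhodamine B assay, with a stated time of 4 days (a higher number here means a weaker inhibitor of growth, a lower number a stronger inhibitor of growth), compound 1 (`COc1cc(Cl)c(-c2nc(SCC(=O)NC3CC3)nc3[nH]cc(C#N)c23)cc1O`) gives 102 nM and compound 2 (`COc1cc(Cl)c(-c2nc(SCC(=O)NC(C)C)nc3[nH]cc(C#N)c23)cc1O`) gives 161 nM. For the measured compounds named here, compound 2 therefore stands within the scatter of compound 1, the only other compound measured, and the two cannot be ranked. Compound 3 (`COc1cc(Cl)c(-c2nc(SCC(=O)NC(C)(C)C)nc3[nH]cc(C#N)c23)cc1O`) differs from compound 2 by one change, methyl in place of hydrogen on a saturated chain carbon bound to an amide-type nitrogen and two saturated chain carbons, which turns isopropyl into tert-butyl. Going by the values given here, no measured step makes this exact change. The one that bears on it also alters the group on an amide-type nitrogen, isopropyl in place of cyclopropyl, and it is small: a 1.6-fold higher number from compound 1 to compound 2 (0.20 log units; within the scatter). On these data alone, no step beyond the scatter is therefore expected in this assay, and the direction stays open. The expected result is a 1.2-fold higher number from compound 2 to compound 3 (0.07 log units; within the scatter). For compound 3 the estimated value is 190 nM, with an expected range of 85 nM to 430 nM.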

Compound 3, concentration for 50% growth inhibition: 128 nM
Compound 3: middle estimate off by 1.5-fold (0.17 log units), on the high side, and the stated range covers the measured number.
By their numbers in this assay, from the lowest: compounds 1, 3 and 2 (each within the scatter of the next).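

In this assay the added methyl on the saturated chain carbon gives a 1.3-fold lower number from compound 2 to compound 3 (0.10 log units; within the scatter) and tert-butyl in place of cyclopropyl on the amide-type nitrogen gives a 1.3-fold higher number from compound 1 to compound 3 (0.10 log units; within the scatter) and so neither step separates the compounds. With tert-butyl, this position now carries three different groups on the amide-type nitrogen, and compound 1, compound 2 and compound 3 still cannot be ranked against one another. Nothing available gives a reason for this reading of the position.

On these data alone, what a longer chain such as n-butyl, a ring such as morpholine or phenyl, or a group bearing a carboxylic acid or an amine would give on this nitrogen stays open. Whether the same reading would hold in a different cell line also remains unanswered.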